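The compounds below may be only part of what the source reports. "The series", "measured", "known", "first", "only" and "open" are said of these compounds alone.

Measured so far:
compound 1, `Clc1ccc(Cn2cc(C3CC(c4ccncc4)=NO3)c3ccccc32)cc1`: > 100000 nM
compound 2, `COc1ccc2c(c1)c(C1CC(c3ccncc3)=NO1)cn2Cc1ccc(Cl)cc1`: > 100000 nM
compound 3, `c1ccc2c(C3CC(c4ccncc4)=NO3)c[nH]c2c1`: 30500 nM

In a functional assay on BXPC-3 cells (Homo sapiens) for inhibition, read by MTT assay, with a stated time of 48 h (on this read-out lower numbers stand for stronger inhibition and higher numbers for weaker inhibition), compound 1 gives only a limit of the assay, > 100000 nM. Compound 2 likewise gives only a limit, > 100000 nM. The change between them, (methoxy in place of hydrogen on an aromatic carbon), therefore made a step that the two limits leave unreadable from compound 1 to compound 2, since both numbers sit at the limit of > 100000 nM in this assay, at which 2 of the 3 values shown sit. For the measured compounds named here, compound 3 is the one compound with a read number, 30500 nM in this assay, and its difference from compound 1 is hydrogen in place of 4-chlorobenzyl on an aromatic nitrogen, which made an at least 3.2-fold lower number from compound 1 to compound 3 (0.51 log units; beyond the scatter).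

Compound 4, `COc1ccc2[nH]cc(C3CC(c4ccncc4)=NO3)c2c1`, is not yet measured. It differs from compound 3 by methoxy in place of hydrogen on an aromatic carbon, the same change as from compound 1 to compound 2, but that earlier step was left unreadable by the two limits. With no readable precedent, compound 4 is expected to stay near compound 3, an estimated step of a 1.0-fold lower number from compound 3 to compound 4 (0.01 log units; within the scatter) in this assay, giving an expected 30000 nM, within 8000 nM to 110000 nM.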

Compound 4, half-maximal inhibitory concentration: 68500 nM
Compound 4: middle estimate off by 2.3-fold (0.36 log units), on the low side; the range from low to high includes it.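

In this assay the methoxy change gives a 2.2-fold higher number from compound 3 to compound 4 (0.35 log units; beyond the scatter), while the same change between the two 4-chlorobenzyl compounds cannot be read, so nothing shows whether this step carries from one core to the other. Hydrogen in place of 4-chlorobenzyl gives an at least 1.4-fold lower number from compound 2 to compound 4 (0.16 log units; that floor lies within the scatter), and beside the earlier step this points the same way on both cores, but only as floors set by limits of the assay: the same change on two cores in this assay, an at least 3.2-fold lower number (0.51 log units; beyond the scatter) from compound 1 to compound 3 and an at least 1.4-fold lower number (0.16 log units; that floor lies within the scatter) from compound 2 to compound 4; the limit leaves it open whether they differ. Going by these compounds, the true size of this step on either core therefore stays unknown, as does any difference between the cores.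

The compounds shown leave open how a longer chain on the aromatic nitrogen would read in this assay. They also leave open how an amine in place of methoxy on the aromatic carbon would read.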